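This account rests on a few compounds, and the source may have more. Where it says the series, first, only, none or still open, it means among the compounds named here.

Measured compounds in an ADME assay on HEK293 cells (Homo sapiens) for cytotoxicity, with a stated time of 72 h; on this read-out lower numbers stand for an effect already at smaller amounts and higher numbers for an effect only at larger amounts of compound:

- Compound 1, `Cc1cc(NC(=O)Nc2ccccc2OC(F)(F)F)c2ccccc2n1`: reported only as a limit, > 25000 nM.
- Compound 2, `CCc1ccc(NC(=O)Nc2cc(C)nc3ccccc23)cc1`: 16000 nM.
- Compound 3, `Cc1cc(NC(=O)Nc2cc(F)cc(F)c2)c2ccccc2n1`: reported only as a limit, > 25000 nM.

Going by the values given here, compound 2 is the one compound of the three with a number in this assay rather than a limit; the other two sit at the limit of > 25000 nM in this assay, at which 2 of the 3 values shown sit. Among the compounds with values here, no two measured compounds differ in a single place, so no measured step is available, and the series gives no direct guide to how a single substituent swap moves this read-out.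

The unmeasured compound 4, `Cc1cc(NC(=O)Nc2ccc(SC(F)(F)F)cc2)c2ccccc2n1`, differs from compound 2 in one place: (trifluoromethyl)sulfanyl in place of ethyl on an aromatic carbon. Within the data shown here, with no measured step to lean on, the expectation for compound 4 in this assay rests on compound 2 alone, at 16000 nM. It also takes into account that compound 1 and compound 3 are reported only as limits. The expected step is small, not clearly beyond the scatter, and if anything toward larger amounts, since two of three values in this read-out are limits. Compound 4 is therefore expected to give about 20000 nM, with a range from 8000 nM to 60000 nM, an estimated step of a 1.3-fold higher number from compound 2 to compound 4 (0.10 log units; within the scatter), and a real chance that only a limit is reported.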

Compound 4, half-maximal effective concentration: 13000 nM
Compound 4: the middle estimate sits 1.5-fold (0.19 log units) above what was measured, within the range that was stated.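

In this assay, putting (trifluoromethyl)sulfanyl in place of ethyl on an aromatic carbon, para to a large group, gives a 1.2-fold lower number from compound 2 to compound 4 (0.09 log units; within the scatter), the only measured single-place step in the compounds shown. A group of 5 heavy atoms, carrying sulfur and fluorine, thus takes the place of a group of 2 heavy atoms of carbon alone, and the read-out does not separate the two. Compound 1 and compound 3 are reported only as limits, and each differs from compound 2 in more than one place, so neither extends this comparison: the limit of > 25000 nM in this assay, at which 2 of the 4 values shown sit.

A single step at this position does not show whether the read-out stays within the scatter for other groups there, such as an amine, a carboxylic acid or a longer chain. It also leaves open whether the numbers for compound 2 and compound 4, as against the limits for compound 1 and compound 3, have anything to do with where the substituent sits on the ring.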